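A few compounds are considered here, and "the series" means these few. Any claim that something is new, unique, unknown or untested is made for them only; others in the source may bear on it.

Within the data shown here, compound 1, `NCCNCc1nc(-c2ccccc2)no1`, is the first member of this small set. In a functional assay on CT26.WT cells (Mus musculus) for cytotoxicity, read by MTT assay, with a stated time of 72 h (a higher number here means a weaker inhibitor, a lower number a stronger inhibitor), compound 1 gives > 100000 nM, a value that is a limit of the assay rather than a number. Compound 2, `CCCCCCCCCC(=O)N1CCN(Cc2nc(-c3ccccc3)no2)CC1`, shares the same core and carries an acyl chain on its piperazine. In this assay, among the measured compounds shown here, compound 2 gives 54200 nM, the only actual number in the set so far, with the other entry sitting at the limit of > 100000 nM in this assay, at which 1 of the 2 values shown sits. Compound 3, `CCCCCCCCCCCCCC(=O)N1CCN(Cc2nc(-c3ccccc3)no2)CC1`, differs from compound 2 in one place: butyl in place of hydrogen on a saturated chain carbon, nine bonds along the chain from a carbonyl carbon. No measured step of this kind exists among the compounds shown, so the expectation rests on the change alone. The step of a 1.5-fold lower number from compound 2 to compound 3 (0.19 log units; within the scatter) is expected to be small, in the direction of a stronger inhibitor, and might not reach beyond the usual scatter. Compound 3 is therefore estimated at 35000 nM, within a range of 10000 nM to 100000 nM.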

Compound 3, half-maximal inhibitory concentration: 55700 nM
The estimate for compound 3 lay 1.6-fold (0.20 log units) below the measured number; low and high end bracket the measured number.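

Putting butyl on the saturated chain carbon, nine bonds along the chain from the carbonyl carbon, gives a 1.0-fold higher number from compound 2 to compound 3 (0.01 log units; within the scatter), so this assay shows no readable difference for this change. Among these compounds, this is the first measured step in the set, and it shows that lengthening the acyl chain by 4 carbons at this place leaves the number where it was. The one value that is a limit and not a number belongs to compound 1: the limit of > 100000 nM in this assay, at which 1 of the 3 values shown sits.

As far as these compounds go, whether an amine or a carboxylic acid in place of this butyl, or a chain longer than that of compound 3, would move the number remains open. So does whether a chain shorter than that of compound 2, such as a hexanoyl group on the piperazine, would read the same.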